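Urea aryl exchange on a thienopyrimidine series

A few compounds are considered here, and "the series" means these few. Any claim that something is new, unique, unknown or untested is made for them only; others in the source may bear on it.

Measured compounds in a functional assay on MDA-MB-231 cells (Homo sapiens) for cytotoxicity, read by MTT assay, with a stated time of 72 h; on this read-out higher numbers stand for weaker inhibition and lower numbers for stronger inhibition:
compound 1 `CN(C)CCNc1nc(-c2ccc(NC(=O)Nc3ccc(Cl)cc3Cl)cc2)nc2ccsc12` gives 2450 nM
compound 2 `Cc1ccc(NC(=O)Nc2ccc(-c3nc(NCCN(C)C)c4sccc4n3)cc2)cc1` gives 2180 nM
compound 3 `CCN(CC)CCCNc1nc(-c2ccc(NC(=O)Nc3ccc(Cl)cc3Cl)cc2)nc2c(Cl)c(Cl)sc12` gives 3940 nM

Compound 1 and compound 2 differ only by 4-methylphenyl in place of 2,4-dichlorophenyl on an amide-type nitrogen, and this gave a 1.1-fold lower number from compound 1 to compound 2 (0.05 log units; within the scatter). Compound 3 carries the same urea aryl group as compound 1 on a different core; the difference between the two cores is not broken down here. Compound 4 `CCN(CC)CCCNc1nc(-c2ccc(NC(=O)Nc3ccc(C)cc3)cc2)nc2c(Cl)c(Cl)sc12` has not been measured and differs from compound 3 by 4-methylphenyl in place of 2,4-dichlorophenyl on an amide-type nitrogen, the same change as from compound 1 to compound 2, at the same place.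

In this assay the step from compound 3 to compound 4 is expected to be a 1.1-fold lower number from compound 3 to compound 4 (0.05 log units; within the scatter), because a 1.1-fold lower number from compound 1 to compound 2 (0.05 log units; within the scatter) was seen on the other core. Compound 4 is accordingly estimated at 3500 nM, with the likely range running from 1700 nM to 7500 nM.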

Compound 4, half-maximal inhibitory concentration: 3040 nM
Compound 4: the middle estimate sits 1.2-fold (0.06 log units) above what was measured, within the range that was stated.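

In this assay, 4-methylphenyl in place of 2,4-dichlorophenyl on the urea nitrogen gave a 1.3-fold lower number from compound 3 to compound 4 (0.11 log units; within the scatter). The change carries over between these two cores with no difference beyond the scatter: the same change on two cores in this assay, a 1.1-fold lower number (0.05 log units; within the scatter) from compound 1 to compound 2 and a 1.3-fold lower number (0.11 log units; within the scatter) from compound 3 to compound 4, 1.2-fold (0.06 log units) apart, within the scatter of two such steps

Within the data shown here, since both steps are themselves within the scatter, this shows only that the exchange stays small on both cores; it does not show that a larger step would carry over in the same way. Open, from the compounds shown here alone, is whether another urea aryl group, such as a phenyl carrying a carboxylic acid or a morpholine, gives a step beyond the scatter and keeps it on both cores. Also open, going by these compounds, is how the dimethylaminoethyl and diethylaminopropyl chains act apart from the rest of each core.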